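From naphthalen-1-yl to 4-chlorophenyl in compound 1

A few compounds are considered here, and "the series" means these few. Any claim that something is new, unique, unknown or untested is made for them only; others in the source may bear on it.

Readings in a functional assay on RS4-11 cells (Homo sapiens) for inhibition, read by CCK-8 assay, with a stated time of 48 h, tested at 20 uM (on this read-out higher numbers stand for more inhibition of growth at the one concentration tested and lower numbers for less inhibition of growth), for the measured compounds
- Compound 1 `N#C/C(=C\c1ccccc1OS(=O)(=O)c1ccc([N+](=O)[O-])cc1)C(=O)Nc1nnc(Cc2cccc3ccccc23)s1` gives 58% here
- Compound 2 `N#C/C(=C\c1ccccc1OS(=O)(=O)c1ccc(Cl)cc1)C(=O)Nc1nnc(Cc2cccc3ccccc23)s1` gives 68% here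
- Compound 3 `N#C/C(=C\c1ccccc1OS(=O)(=O)c1ccc(F)cc1)C(=O)Nc1nnc(Cc2cccc3ccccc23)s1` gives 68% here

Compound 1 stands within the scatter of both other compounds. Compound 4 `N#C/C(=C\c1ccccc1OS(=O)(=O)c1ccc([N+](=O)[O-])cc1)C(=O)Nc1nnc(Cc2ccc(Cl)cc2)s1` carries 4-chlorophenyl in place of naphthalen-1-yl on a saturated chain carbon bound to an aromatic carbon. Among the measured compounds shown here, no measured step touches that place. The measured steps swap only nitro, chloro and fluoro elsewhere: a number 10 percentage points higher from compound 1 to compound 2 (within the scatter), a number 10 percentage points higher from compound 1 to compound 3 (within the scatter) and no change at the digits printed from compound 2 to compound 3 (within the scatter). They bear on this change only indirectly and give it no direction, so the expectation stays close to compound 1 at 58% and none beyond the scatter is foreseen, though with wide uncertainty. The estimated step is a number 3 percentage points lower from compound 1 to compound 4 (within the scatter). Compound 4 is expected at 55% (estimated range 34% to 74%).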

Compound 4, percent growth inhibition at one concentration: 66%
Compound 4: the middle estimate sits 11 percentage points below what was measured; the measured number falls inside the stated range.
By their numbers in this assay, from the lowest: compounds 1, 4, 2 and 3 (each within the scatter of the next).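

In this assay, replacing naphthalen-1-yl with 4-chlorophenyl on a saturated chain carbon bound to an aromatic carbon gives a number 8 percentage points higher from compound 1 to compound 4 (within the scatter). With the nitro group held fixed, one six-membered aromatic ring in place of two therefore leaves the step at this place within the scatter. No independent measurement accounts for this step.

The compounds shown leave open whether an amine, a carboxylic acid or a longer chain at this place would keep the read-out within the scatter. They also leave open how 4-chlorophenyl behaves with chloro or fluoro in place of nitro.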